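Aminotriazole thioether ketones: aryl ketone variation

A few compounds are considered here, and "the series" means these few. Any claim that something is new, unique, unknown or untested is made for them only; others in the source may bear on it.

Compound 1 `COc1cc(-c2nnc(SCC(=O)c3ccc(Cl)cc3)n2N)cc(OC)c1OC` — in a functional assay on PC-3 cells (Homo sapiens) for antiproliferative activity, read by MTT assay, with a stated time of 48 h (a lower number here means a stronger inhibitor, a higher number a weaker inhibitor), compound 1 gives > 100000 nM, a limit of the assay and not a number.
Compound 2 `COc1cc(-c2nnc(SCC(=O)c3ccc(C)cc3)n2N)cc(OC)c1OC` — in this assay compound 2 gives 31300 nM.
Compound 3 `COc1cc(-c2nnc(SCC(=O)c3ccc(F)c(F)c3)n2N)cc(OC)c1OC` — in this assay compound 3 gives > 100000 nM, again only a limit.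

Compound 3 stands at the upper limit of this assay, where two of the three values sit (the limit of > 100000 nM in this assay, at which 2 of the 3 values shown sit). Only compound 2, carrying 4-methylphenyl, gives a number; the step of an at least 3.1-fold higher number from compound 2 to compound 3 (0.50 log units; beyond the scatter) is the one readable move onto the 3,4-difluorophenyl ketone, while a step that the two limits leave unreadable from compound 1 to compound 3 runs from one limit to another and cannot be sized.

Compound 4 `COc1cc(-c2nnc(SCC(=O)c3ccccc3F)n2N)cc(OC)c1OC` differs from compound 3 by 2-fluorophenyl in place of 3,4-difluorophenyl on a carbonyl carbon. Among the compounds with values here, no measured step tests this change directly: the halogenated ketones (compound 1, compound 3) both sit at the limit, and the only numerical value belongs to the methyl ketone, compound 2. A single fluorine on the ketone aryl ring is expected to leave compound 4 close to where compound 3 stands, with an at least 1.2-fold lower number from compound 3 to compound 4 (0.09 log units; that floor lies within the scatter) as the expected step, and a fair chance that only a limit is returned. For compound 4 the estimate in this assay is 80000 nM, between 25000 nM and 250000 nM.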

Compound 4, half-maximal inhibitory concentration: 43100 nM
For compound 4 the middle estimate is 1.9-fold (0.27 log units) above the measured one, within the range that was stated.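

Compound 4 is the first ketone carrying a halogen to give a number rather than a limit in this assay, so a halogen on this aryl ring does not by itself put a compound at the limit, although compound 1 and compound 3 stay there: the limit of > 100000 nM in this assay, at which 2 of the 4 values shown sit.

The move off the limit reads as an at least 2.3-fold lower number from compound 3 to compound 4 (0.36 log units; beyond the scatter), and the comparison with the chlorinated ketone reads as an at least 2.3-fold lower number from compound 1 to compound 4 (0.36 log units; beyond the scatter), so the substitution on the aryl ring attached to the carbonyl carbon does separate these compounds, even if the limits hide the full size of both steps. Against the methyl ketone the reading is a 1.4-fold higher number from compound 2 to compound 4 (0.14 log units; within the scatter), so 2-fluorophenyl and 4-methylphenyl cannot be told apart here, and the methyl group no longer stands alone as the only substituent giving a number.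

Compound 3 and compound 4 differ both in the number of fluorines and in where they sit, and the compounds shown do not separate these two changes. Also open, going by these compounds, is how this aryl ring would read with no substituent at all, or with an amine or a carboxylic acid on it.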